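Swapping chloro for bromo on a dichloro-bromo aryl triazine

A few compounds are considered here, and "the series" means these few. Any claim that something is new, unique, unknown or untested is made for them only; others in the source may bear on it.

Measured so far in a functional assay on the whole organism with Rattus norvegicus as the target, at a dose of 20 mg/kg by the intraperitoneal route; a lower number here means less inhibition, a higher number more inhibition at the dose given (going by the name of the read-out):
- compound 1, `Nc1nc(N)nc(-c2cccc(Br)c2)n1`: 96%
- compound 2, `Nc1nc(N)nc(-c2cc(Br)ccc2Cl)n1`: 86%
- compound 3, `Nc1nc(N)nc(-c2cc(Cl)ccc2Br)n1`: 81%

All three share the same core, a diamino-triazine carrying a halogenated phenyl ring. Compound 1 carries a single bromo group and gives the highest inhibition of the three in this assay. Compound 3 stands lowest of the three numbers; its gap to compound 2 lies within the scatter, so the two cannot be told apart, while its gap to compound 1 is beyond the scatter.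

Compound 4, `Nc1nc(N)nc(-c2cc(Br)ccc2Br)n1`, has not yet been tested. It differs from compound 3 in one place: bromo in place of chloro on an aromatic carbon. Going by the values given here, the only measured step, a number 10 percentage points lower from compound 1 to compound 2 (within the scatter), concerns a chloro entering where hydrogen stood, not a chloro being replaced by bromo, so it bears on the new change only loosely. Compound 2 and compound 3 show that shifting the two halogens between their positions leaves the inhibition within the scatter. Taken together, little movement is expected in this assay.

Compound 4 is therefore expected to give about 83%, between 70% and 95%, a step of a number 2 percentage points higher from compound 3 to compound 4 (within the scatter) that stays within the scatter.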

Compound 4, a percentage reported as inhibition, in the whole organism at one dose (the size of the read-out at that dose, not a potency) in the Rattus norvegicus assay: 43%
Compound 4: middle estimate off by 40 percentage points, on the high side, and the stated range ends above it.
By their numbers in the Rattus norvegicus assay, from the lowest: compound 4; then compounds 3, 2 and 1 (each within the scatter of the next, the first and the last beyond it).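

In the Rattus norvegicus assay, trading a chloro for a bromo on the aromatic ring proves far from neutral: the change gives a number 38 percentage points lower from compound 3 to compound 4 (beyond the scatter), and the same exchange made at the other halogen gives a number 43 percentage points lower from compound 2 to compound 4 (beyond the scatter). Among these compounds the sharp fall comes only when both halogens are bromo, since a bromo in place of hydrogen gives a number 53 percentage points lower from compound 1 to compound 4 (beyond the scatter), whereas a chloro in place of that same hydrogen gives only a number 10 percentage points lower from compound 1 to compound 2 (within the scatter). In a physicochemical assay for lipophilicity (a higher number here means a more lipophilic compound, a lower number a more polar compound), compound 3 gives 1.85 and compound 4 gives 2.09, two numbers within the usual scatter of each other, and nothing available accounts for the fall in inhibition.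

Going by these compounds, it remains open whether the fall belongs to bromo alone or would also follow from another group at this place, such as a methyl, a methoxy or an amine. Since the Rattus norvegicus assay reports the effect in the whole animal at a single dose, these numbers also cannot tell whether compound 4 is weaker at its target or simply acts less well in the body.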